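The source may hold more compounds than are shown below. What is called first, only, known or untested is meant among the compounds shown, and "the series" means these compounds.

Measured compounds:
compound 1, `Cc1ccc(-c2nc(CNc3ccc(C(=O)NO)cc3)n(-c3ccccc3)n2)cc1`, 62.2%
compound 2, `O=C(NO)c1ccc(NCc2nc(-c3cccc4cnccc34)nn2-c2ccccc2)cc1`, 40.2%

In an assay on Sf9 cells for inhibition of protein deacetylase HDAC6 (Homo sapiens), read by fluorescence, with a stated time of 40 min, tested at 100 nM (a higher number here means more inhibition at the concentration tested (going by the name of the read-out), a lower number less inhibition), compound 1 stands highest of the two numbers measured; its nearest neighbour is compound 2, which is a number 22 percentage points lower from compound 1 to compound 2 (beyond the scatter), a change recorded as beyond the scatter and of modest size.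

Compound 3, `O=C(NO)c1ccc(NCc2nc(-c3cc4ccccc4s3)nn2-c2ccccc2)cc1`, has not yet been measured in this assay. It differs from compound 1 in one place: 1-benzothiophen-2-yl in place of 4-methylphenyl on an aromatic carbon.

Going by the values given here, the only measured step that bears on this change is the one from compound 1 to compound 2, where a two-ring aromatic group also took the place of 4-methylphenyl on the same aromatic carbon and the read-out was a number 22 percentage points lower from compound 1 to compound 2 (beyond the scatter). On that single precedent a step of comparable direction is expected for compound 3, though no two-ring group with one sulfur has been measured, so the size is uncertain. Compound 3 is therefore estimated to give 48% in this assay, within 28% to 68%, which would mean a number 14.2 percentage points lower from compound 1 to compound 3 (beyond the scatter).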

Compound 3, a percentage reported as inhibition, at one concentration (the size of the read-out at that concentration, not a potency): 65.5%
Compound 3: the middle estimate sits 17.5 percentage points below what was measured, and the stated range covers the measured number.
By their numbers in this assay, from the lowest: compound 2; then compounds 1 and 3 (each within the scatter of the next).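

In this assay, the aromatic carbon of the five-membered ring with 3 nitrogen can carry a two-ring group and still read level with 4-methylphenyl, with a number 3.3 percentage points higher from compound 1 to compound 3 (within the scatter). The lower number for isoquinolin-5-yl therefore does not follow from a second ring as such, since the two two-ring groups themselves differ, with a number 25.3 percentage points higher from compound 2 to compound 3 (beyond the scatter). No measurement at hand accounts for that difference between them. With only three groups shown at this place, it stays open whether benzofuran-2-yl, with oxygen in place of the sulfur, or a single-ring thiophen-2-yl would stand with compound 1 and compound 3 or with compound 2. Going by these compounds, an amine or a carboxylic acid at the same carbon is equally open, as is any change to the phenyl group of the core.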